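A Benzyl Group Tried in Place of Methoxy

This account rests on a few compounds, and the source may have more. Where it says the series, first, only, none or still open, it means among the compounds named here.

Compound 3 `COCCC1=C(N2CC2)C(=O)C(C)=C(N2CC2)C1=O` stands lowest of the three compounds measured in a functional assay on L1210 cells (Mus musculus), with a stated time of 12 days (a lower number here means a less potent compound, a higher number a more potent compound, by a factor of ten per unit of this negative logarithm), at 5.57. Compound 1 `CC1=C(N2CC2)C(=O)C(CC(C)OC(N)=O)=C(N2CC2)C1=O` gives 6.14 and compound 2 `CC1=C(N2CC2)C(=O)C(CCCOC(N)=O)=C(N2CC2)C1=O` gives 6.18; the step of a number 0.04 log units higher from compound 1 to compound 2 (within the scatter) lies within the scatter, whereas a number 0.57 log units lower from compound 1 to compound 3 (beyond the scatter) and a number 0.61 log units lower from compound 2 to compound 3 (beyond the scatter) both lowered the value beyond it. Compound 4 `CC1=C(N2CC2)C(=O)C(CCCc2ccccc2)=C(N2CC2)C1=O` differs from compound 3 in one place: benzyl in place of methoxy on a saturated chain carbon, two bonds along the chain from a double-bonded ring carbon. Among the measured compounds shown here, the two earlier steps show that the (carbamoyloxy)methyl-bearing chains outperformed the short methoxy group, but no measured compound carries a benzyl group, so the change is only loosely anchored. A modest gain is therefore expected for compound 4, a number 0.28 log units higher from compound 3 to compound 4 (within the scatter), giving an estimate of 5.85 with a range from 5.25 to 6.45.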

Compound 4, logarithm of the reciprocal of the active concentration, log(1/C): 4.47
Compound 4: the middle estimate sits 1.38 log units above what was measured, outside the stated range (below it).
By their numbers in this assay, from the lowest: compound 4; then compound 3; then compounds 1 and 2 (each within the scatter of the next).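

At this position, benzyl in place of methoxy is a large loss in this assay, with a number 1.10 log units lower from compound 3 to compound 4 (beyond the scatter), so the chain is not merely favoured by added size. Phenyl in place of carbamoyloxy gives a number 1.71 log units lower from compound 2 to compound 4 (beyond the scatter), and replacing the branched carbamoyloxy chain gives a number 1.67 log units lower from compound 1 to compound 4 (beyond the scatter), which places the phenyl-ended chain well under both carbamoyloxy chains. Nothing on hand accounts for this loss. As far as these compounds go, whether an amine or a carboxylic acid at the chain end would recover the value remains open, as does the effect of a hydroxyl group there.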